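From a Substituted Ethenyl to an Ethynyl Amide

A few compounds are considered here, and "the series" means these few. Any claim that something is new, unique, unknown or untested is made for them only; others in the source may bear on it.

In a functional assay on A-375 cells (Homo sapiens) for inhibition, read by MTT assay, with a stated time of 120 h (a lower number here means a stronger inhibitor, a higher number a weaker inhibitor), compound 1 (`O=C(/C=C/c1ccc(NC(=O)Nc2ccc(Cl)c(C(F)(F)F)c2)cc1)NC1CCC1`) gives 15400 nM as its half-maximal inhibitory concentration. Compound 2 (`CNC(=O)/C=C(\C)c1ccc(NC(=O)Nc2ccc(Cl)c(C(F)(F)F)c2)cc1`) gives > 50000 nM in the same read-out, and this is a limit of the assay and not a number. From the compounds shown here alone, compound 2 is thus the weaker of the two, but its true position is unknown.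

Compound 3 (`CNC(=O)C#Cc1ccc(NC(=O)Nc2ccc(Cl)c(C(F)(F)F)c2)cc1`) comes from compound 2 by one change on an aromatic carbon, with 2-(methylcarbamoyl)ethynyl in place of 1-methyl-2-(methylcarbamoyl)ethenyl (2-(methylcarbamoyl)ethynyl in place of 1-methyl-2-(methylcarbamoyl)ethenyl on an aromatic carbon). For the measured compounds named here, only one measured step bears on this position, an at least 3.2-fold higher number from compound 1 to compound 2 (0.51 log units; beyond the scatter) and it lies beyond the scatter. That step ends at a limit and brings in a different amide group, so it offers no firm size for the new change.

Compound 3 keeps the methylcarbamoyl group of compound 2, so weak inhibition is still expected in this assay with only a small gain, if any can be seen. The expected change is an at least 1.6-fold lower number from compound 2 to compound 3 (0.22 log units; that floor lies within the scatter) and may not be resolved from the limit. For compound 3 the estimated value is 30000 nM with an expected range from 10000 nM to 70000 nM in this read-out.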

Compound 3, half-maximal inhibitory concentration: > 50000 nM
Compound 3: no number, only a limit; the forecaster's own chance of this, stated with the estimate: 45%; at least 1.6-fold (0.22 log units) between middle value and limit.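

Exchanging the 1-methyl-2-(methylcarbamoyl)ethenyl group for 2-(methylcarbamoyl)ethynyl brings no measurable value into this assay: compound 3 gives > 50000 nM, which is a limit of the assay and not a number. The step from the ethenyl compound to the ethynyl compound cannot be read, because both end at the same limit: the limit of > 50000 nM in this assay, at which 2 of the 3 values shown sit.

What the result adds is that the loss against the 2-(cyclobutylcarbamoyl)ethenyl group is not confined to a methyl-substituted ethenyl group, since the ethynyl group also shows an at least 3.2-fold higher number from compound 1 to compound 3 (0.51 log units; beyond the scatter).

The compounds shown leave open how far the two methylcarbamoyl groups truly lie from each other, and how much of the loss belongs to the amide end and how much to the unsaturated chain that carries it. They also leave open whether a carboxylic acid or an amine at the end of the ethynyl chain, in place of the methylcarbamoyl group, would give a real number in this assay.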